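Cinnamamide series on the shared core: forecast for compound 4

The compounds below may be only part of what the source reports. "The series", "measured", "known", "first", "only" and "open" are said of these compounds alone.

Measured in a functional assay on HT-29 cells (Homo sapiens) for cytotoxicity, read by MTT assay, with a stated time of 72 h; a higher number here means a weaker inhibitor, a lower number a stronger inhibitor:
compound 1 `COc1ccc(C(=O)c2cc(OC)c(OC)c(OC)c2)cc1N`, 50 nM
compound 2 `C#CCOc1cccc(/C=C/C(=O)Nc2cc(C(=O)c3cc(OC)c(OC)c(OC)c3)ccc2OC)c1`, 7400 nM
compound 3 `COc1cc(/C=C/C(=O)Nc2cc(C(=O)c3cc(OC)c(OC)c(OC)c3)ccc2OC)ccc1F`, 7700 nM

Compound 3 gives the highest number of the three; compound 2 sits within the scatter of it, while compound 1, the free amine without the acylated chain, gives a far lower number. Compound 4 `COc1ccc(C(=O)c2cc(OC)c(OC)c(OC)c2)cc1NC(=O)/C=C/c1ccc(N)cc1` carries 4-aminophenyl in place of 4-fluoro-3-methoxyphenyl on a double-bonded chain carbon bound to a double-bonded chain carbon. Among the measured compounds shown here, only one measured step bears on a swap of the aryl group on this chain: a 1.0-fold higher number from compound 2 to compound 3 (0.02 log units; within the scatter), nothing beyond the scatter. Both acylated compounds sit far from compound 1, so among these compounds the aryl group on the chain has not moved the number; this rests on two pairs only. The expected step is therefore a 1.1-fold lower number from compound 3 to compound 4 (0.04 log units; within the scatter), none beyond the scatter. Compound 4 is estimated at 7000 nM, range 2500 nM to 20000 nM.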

Compound 4, half-maximal inhibitory concentration: 5600 nM
The estimate for compound 4 lay 1.3-fold (0.10 log units) above the measured number; the measured number falls inside the stated range.
By their numbers in this assay, from the lowest: compound 1; then compounds 4, 2 and 3 (each within the scatter of the next).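

In this assay the 4-aminophenyl group brings a hydrogen-bond donor that 4-fluoro-3-methoxyphenyl lacks, yet the number stays within the scatter, with a 1.4-fold lower number from compound 3 to compound 4 (0.14 log units; within the scatter) and a 1.3-fold lower number from compound 2 to compound 4 (0.12 log units; within the scatter). The large change still comes with the chain on the nitrogen, with a 110-fold higher number from compound 1 to compound 4 (2.05 log units; beyond the scatter), so a third aryl group now joins the same level. Nothing available here accounts for either result.

Still open, on these data alone, is whether a carboxylic acid on this aryl ring would move the number. A longer chain in place of the two double-bonded carbons also remains untested in the compounds shown here.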